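Swapping Chloro for Fluoro on a Shared Core

The compounds below may be only part of what the source reports. "The series", "measured", "known", "first", "only" and "open" are said of these compounds alone.

Compound 1 has the structure `CC1=C(C(=O)Nc2ccc(F)cc2)C(c2ccc([N+](=O)[O-])cc2)N=C(SCc2ccc(Cl)cc2)N1`. In a functional assay on the whole organism (artery, strain albino) with Rattus norvegicus as the target, with a stated time of 60 min, at a dose of 10 mg/kg by the oral route (on this read-out higher numbers stand for more inhibition at the one dose given (going by the name of the read-out) and lower numbers for less inhibition), compound 1 gives 11.8%. Compound 2, with the structure `CC1=C(C(=O)Nc2ccc(F)cc2)C(c2ccc([N+](=O)[O-])cc2)N=C(SCc2ccc(F)cc2)N1`, differs from compound 1 in one place only: fluoro in place of chloro on an aromatic carbon. In this assay compound 2 gives 10.8%, so that the change made a step of a number 1 percentage points lower from compound 1 to compound 2 (within the scatter).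

Compound 3 has the structure `CC1=C(C(=O)Nc2ccc(Br)cc2)C(c2ccc(Cl)cc2Cl)N=C(SCc2ccc(Cl)cc2)N1`. It differs from compound 1 in more than one place, and the difference between the two cores is not broken down here. In this assay compound 3 gives 11.8%, which stands level with compound 1 at the digits given and is within the scatter of compound 2 as well.

Compound 4, with the structure `CC1=C(C(=O)Nc2ccc(Br)cc2)C(c2ccc(Cl)cc2Cl)N=C(SCc2ccc(F)cc2)N1`, has not yet been measured. Among the compounds with values here, it differs from compound 3 by fluoro in place of chloro on an aromatic carbon, which is the same change, in the same place, as the one from compound 1 to compound 2.

Because that earlier change produced only a number 1 percentage points lower from compound 1 to compound 2 (within the scatter), a step that lies within the scatter, the expectation for compound 4 is a step of similar size, namely a number 0.8 percentage points lower from compound 3 to compound 4 (within the scatter). On that basis compound 4 is estimated to give 11% in this assay, with an expected range from 3% to 19%. This rests on a single earlier pair, so the estimate is a loose one.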

Compound 4, a percentage reported as inhibition, in the whole organism at one dose (the size of the read-out at that dose, not a potency): 16.9%
Compound 4: the middle estimate sits 5.9 percentage points below what was measured; low and high end bracket the measured number.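

In this assay, the change from (4-chlorobenzyl)sulfanyl to (4-fluorobenzyl)sulfanyl gave a number 5.1 percentage points higher from compound 3 to compound 4 (within the scatter) on the second core. Within the data shown here, this shows only that, on the two cores seen here, the swap produced no step that can be told apart from the ordinary spread of repeated measurements, so the two cores give no sign of treating it differently. It does not show that the swap is without effect in general, or that the same would hold on a third core, since two pairs measured at one dose make a thin basis and a real but small difference could hide inside that spread. The two steps, set side by side, read as follows: the same change on two cores in this assay, a number 1 percentage points lower (within the scatter) from compound 1 to compound 2 and a number 5.1 percentage points higher (within the scatter) from compound 3 to compound 4, 6.1 percentage points apart, within the scatter of two such steps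

The compounds shown carry only chloro or fluoro at this place on the benzyl group, so it remains open what an amine, a carboxylic acid or a methoxy group there would do, or a longer chain in place of the benzyl group. A single dose and a single time point also leave open how these compounds would compare across a range of doses, where differences hidden at one dose might appear.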